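Moving the Chlorine on the Benzyl Group of Compound 3

The compounds below may be only part of what the source reports. "The series", "measured", "known", "first", "only" and "open" are said of these compounds alone.

Compound 1 `COc1ccc(CN2CCC(CCNC(=O)/C=C/c3cc(C(C)(C)C)c(O)c(C(C)(C)C)c3)CC2)cc1`: 72500 nM
Compound 2 `CC(C)(C)c1cc(/C=C/C(=O)NCCC2CCN(Cc3ccc(F)cc3F)CC2)cc(C(C)(C)C)c1O`: 70600 nM
Compound 3 `CC(C)(C)c1cc(/C=C/C(=O)NCCC2CCN(Cc3ccccc3Cl)CC2)cc(C(C)(C)C)c1O`: 72100 nM

In an assay on isolated protein for inhibition of Amine oxidase [flavin-containing] A (Homo sapiens), read by fluorescence, with stated times of 15 min and 20 min (a lower number here means a stronger inhibitor, a higher number a weaker inhibitor), compound 3 sits among the three numbers without separating from either neighbour: compound 1 is nearest, with a 1.0-fold lower number from compound 1 to compound 3 (0.00 log units; within the scatter), and compound 2 is the other, with a 1.0-fold higher number from compound 2 to compound 3 (0.01 log units; within the scatter). Compound 4 `CC(C)(C)c1cc(/C=C/C(=O)NCCC2CCN(Cc3cccc(Cl)c3)CC2)cc(C(C)(C)C)c1O` differs from compound 3 by 3-chlorophenyl in place of 2-chlorophenyl on a saturated chain carbon bound to an amine nitrogen in a ring. Within the data shown here, the steps that bear on this change are a 1.0-fold lower number from compound 1 to compound 2 (0.01 log units; within the scatter), a 1.0-fold lower number from compound 1 to compound 3 (0.00 log units; within the scatter) and a 1.0-fold higher number from compound 2 to compound 3 (0.01 log units; within the scatter), all within the scatter, so swapping the aromatic group on that carbon has so far shifted nothing. Compound 4 is therefore expected to show a 1.0-fold lower number from compound 3 to compound 4 (0.00 log units; within the scatter), no step beyond the scatter in either direction. The estimate for compound 4 is 72000 nM, with a range from 36000 nM to 145000 nM.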

Compound 4, half-maximal inhibitory concentration: 65100 nM
Compound 4: middle estimate off by 1.1-fold (0.04 log units), on the high side; low and high end bracket the measured number.
By their numbers in this assay, from the lowest: compounds 4, 2, 3 and 1 (each within the scatter of the next).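

Moving the chlorine, from 2-chlorophenyl to 3-chlorophenyl with the same atoms, gives a 1.1-fold lower number from compound 3 to compound 4 (0.04 log units; within the scatter) in this assay, so changing where the chlorine sits on this phenyl group has not shifted the reading beyond normal variation. The other comparisons agree, with a 1.1-fold lower number from compound 2 to compound 4 (0.04 log units; within the scatter) and a 1.1-fold lower number from compound 1 to compound 4 (0.05 log units; within the scatter). No measurement shown gives a reason for this flat result.

Still open, from the compounds shown here alone, is whether any group on this carbon can separate from the rest. A phenyl group carrying a carboxylic acid or an amine might answer that.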